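The compounds below may be only part of what the source reports. "The series", "measured", "known", "first", "only" and "open" are said of these compounds alone.

Measured so far in a toxicity assay on L02 cells (Homo sapiens) for cytotoxicity, read by MTT assay, with a stated time of 24 h; on this read-out higher numbers stand for lower toxicity in this test and lower numbers for higher toxicity in this test:
- compound 1, `CCCCS(=O)(=O)Oc1ccc(/C=C/C(=O)Nc2ccccc2Br)cc1OC`, gives 5000 nM
- compound 2, `CCCCS(=O)(=O)Oc1ccc(/C=C/C(=O)Nc2ccccc2C)cc1OC`, gives 56100 nM
- compound 3, `CCCCS(=O)(=O)Oc1ccc(/C=C/C(=O)OCC(C)C)cc1OC`, gives 63800 nM

Compound 3 has the highest number of the three, that is, the lowest toxicity seen here. Its distance to compound 2 lies within the scatter, so the two cannot be ranked, while its distance to compound 1 is large: a 13-fold higher number from compound 1 to compound 3 (1.11 log units; beyond the scatter).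

Compound 4, `CCCCS(=O)(=O)Oc1ccc(/C=C/C(=O)OCCC)cc1OC`, differs from compound 3 in one place: hydrogen in place of methyl on a saturated chain carbon bound to two saturated chain carbons. None of the three measured steps touches this chain. The large ones, an 11-fold higher number from compound 1 to compound 2 (1.05 log units; beyond the scatter) and a 13-fold higher number from compound 1 to compound 3 (1.11 log units; beyond the scatter), concern the bromo on the aromatic carbon or the exchange of the whole (2-bromophenyl)amino group on the carbonyl carbon, and the small one, a 1.1-fold higher number from compound 2 to compound 3 (0.06 log units; within the scatter), puts isobutoxy in place of (2-methylphenyl)amino. There is thus no direct guide for trimming one carbon from the chain, a change that adds no ring, donor or acceptor. No step beyond the scatter is expected in this assay, in either direction. Compound 4 is therefore estimated at 60000 nM, with a range from 30000 nM to 120000 nM. The expected step is a 1.1-fold lower number from compound 3 to compound 4 (0.03 log units; within the scatter).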

Compound 4, half-maximal cytotoxic concentration: 61800 nM
The estimate for compound 4 lay 1.0-fold (0.01 log units) below the measured number; measured number inside the range.
By their numbers in this assay, from the lowest: compound 1; then compounds 2, 4 and 3 (each within the scatter of the next).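

In this assay, trimming the isobutoxy group to propoxy leaves the number unchanged within the scatter (a 1.0-fold lower number from compound 3 to compound 4 (0.01 log units; within the scatter)), so the methyl on this saturated chain carbon bound to two saturated chain carbons can be lost without a readable effect on toxicity in this test. The propoxy compound also cannot be told apart from the compound carrying (2-methylphenyl)amino (a 1.1-fold higher number from compound 2 to compound 4 (0.04 log units; within the scatter)), while, like isobutoxy, it stands far from the compound carrying (2-bromophenyl)amino (a 12-fold higher number from compound 1 to compound 4 (1.09 log units; beyond the scatter)). Nothing available here bears on why these numbers fall as they do.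

Still open is whether a longer chain such as hexyloxy, or a carboxylic acid in place of the ester, would stay within the scatter of these compounds. Also open, on these data alone, is whether chloro in place of bromo on the aromatic carbon would keep the low number of compound 1.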